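From a Cyclic to an Open Amine on a Shared Core

The compounds below may be only part of what the source reports. "The series", "measured", "known", "first", "only" and "open" are said of these compounds alone.

Of the compounds shown here, three built on one shared core have been measured in an assay on cells for inhibition of Amine oxidase [flavin-containing] A (Homo sapiens), read by fluorescence, with a stated time of 30 min, tested at 10 uM; on this read-out higher numbers stand for more inhibition at the one concentration tested (going by the name of the read-out) and lower numbers for less inhibition. Compound 1 `COc1ccccc1CN(C)Cc1ccc(/C=C2\Oc3cc(OC)c(OC)cc3C2=O)cc1O` gives 16.3%, compound 2 `CCN(Cc1ccccc1)Cc1ccc(/C=C2\Oc3cc(OC)c(OC)cc3C2=O)cc1O` gives 17%, and compound 3 `COc1cc2c(cc1OC)C(=O)/C(=C/c1ccc(CN3CCCCC3)c(O)c1)O2` gives 15.3%. Compound 3 holds the lowest of the three numbers, yet it is separated from the others only by steps within the scatter: a number 1 percentage points lower from compound 1 to compound 3 (within the scatter) and a number 1.7 percentage points lower from compound 2 to compound 3 (within the scatter). The third measured step, a number 0.7 percentage points higher from compound 1 to compound 2 (within the scatter), is likewise within the scatter.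

Compound 4 `CCN(CC)Cc1ccc(/C=C2\Oc3cc(OC)c(OC)cc3C2=O)cc1O` has not yet been measured. It differs from compound 3 at the amine alone: diethylamino in place of piperidin-1-yl on a saturated chain carbon bound to an aromatic carbon.

All three measured steps concern the same place, a saturated chain carbon bound to an aromatic carbon, and each exchanges one amine for another there; none of them moved the read-out beyond the scatter. The change from compound 3 to compound 4 is of the same kind, so no step beyond the scatter is expected in this assay, in either direction. Compound 4 is therefore expected to give about 15.5%, with a range from 8% to 24%. The step this estimate means, a number 0.2 percentage points higher from compound 3 to compound 4 (within the scatter), is expected to remain within the scatter.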

Compound 4, a percentage reported as inhibition, at one concentration (the size of the read-out at that concentration, not a potency): 22.7%
Compound 4: middle estimate off by 7.2 percentage points, on the low side; the measured number falls inside the stated range.
By their numbers in this assay, from the lowest: compounds 3, 1, 2 and 4 (each within the scatter of the next).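

Among these compounds, exchanging the ring for an open amine, diethylamino in place of piperidin-1-yl on a saturated chain carbon bound to an aromatic carbon, gives a number 7.4 percentage points higher from compound 3 to compound 4 (within the scatter) in this assay, so this change too leaves the read-out unresolved, even though its step is larger in size than any seen among the earlier compounds. Diethylamino, which carries no benzyl group, is equally unresolved from the two benzyl-bearing amines, with a number 5.7 percentage points higher from compound 2 to compound 4 (within the scatter) and a number 6.4 percentage points higher from compound 1 to compound 4 (within the scatter), so at this position neither the ring nor the benzyl group separates any of these compounds in this assay. No information is available on what lies behind these numbers.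

Going by these compounds, it remains open whether a different amine at this place, such as morpholin-4-yl or dimethylamino, or a longer chain carrying the diethylamino group, would give a step beyond the scatter. Since every number here comes from a single concentration, the compounds shown also leave open how these amines would compare at other concentrations.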